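Replacing Naphthalen-1-yl with Phenoxy on the Shared Core

A few compounds are considered here, and "the series" means these few. Any claim that something is new, unique, unknown or untested is made for them only; others in the source may bear on it.

Of the compounds shown here, three sharing one core have been tested in a functional assay on CHO.K1 cells for antagonist activity at prostaglandin D2 receptor 2 (Homo sapiens), read by GTPgammaS binding, with a stated time of 1 h; on this read-out higher numbers stand for weaker inhibition and lower numbers for stronger inhibition. Compound 1 `COc1cccc(S(=O)(=O)c2ccccc2Cc2c3c(n(CC(=O)O)c2C)CCNC3=O)c1` gives 12 nM. Compound 2 `Cc1c(Cc2ccccc2C(O)c2ccccc2)c2c(n1CC(=O)O)CCNC2=O` gives 32 nM, and compound 3 `Cc1c(Cc2ccccc2-c2cccc3ccccc23)c2c(n1CC(=O)O)CCNC2=O` gives 480 nM. Compound 3 thus shows the highest number of the three and is the weakest inhibitor, since the steps of a 40-fold higher number from compound 1 to compound 3 (1.60 log units; beyond the scatter) and a 15-fold higher number from compound 2 to compound 3 (1.18 log units; beyond the scatter) are both large, while the step of a 2.7-fold higher number from compound 1 to compound 2 (0.43 log units; beyond the scatter) is only modest.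

Compound 4 `Cc1c(Cc2ccccc2Oc2ccccc2)c2c(n1CC(=O)O)CCNC2=O` differs from compound 3 by phenoxy in place of naphthalen-1-yl on an aromatic carbon. Both large steps that end at compound 3 end with naphthalen-1-yl, a fused two-ring group joined directly to the aromatic carbon, and both begin from groups in which a phenyl ring hangs from a linking group, as it does in phenoxy. Those two steps bear directly on the present change, which runs the other way, so a large drop in the number is expected, roughly undoing the loss seen in this assay. The expected step is a 12-fold lower number from compound 3 to compound 4 (1.08 log units; beyond the scatter), placing compound 4 near compounds 1 and 2. Compound 4 is estimated to give about 40 nM, with a range from 10 nM to 160 nM.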

Compound 4, half-maximal inhibitory concentration: 530 nM
For compound 4 the middle estimate is 13-fold (1.12 log units) below the measured one; the measured number lies above the stated range.
By their numbers in this assay, from the lowest: compound 1; then compound 2; then compounds 3 and 4 (each within the scatter of the next).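

In this assay, putting phenoxy in place of naphthalen-1-yl on this aromatic carbon, ortho to a large group, gives a 1.1-fold higher number from compound 3 to compound 4 (0.04 log units; within the scatter). The fused two-ring group and the single phenyl ring joined through oxygen therefore cannot be told apart here, so a phenyl ring hanging from a linking group does not by itself give the low numbers of the two other compounds. The link matters as well, as a 17-fold higher number from compound 2 to compound 4 (1.22 log units; beyond the scatter) and a 44-fold higher number from compound 1 to compound 4 (1.65 log units; beyond the scatter) are both large steps, and no measurement shown explains why these linked groups differ so much.

The compounds shown do not separate the effect of the link from that of the substituent on the ring, since the sulfonyl group of compound 1 also carries a methoxy group on its phenyl ring. Plain phenylsulfonyl and 3-methoxyphenoxy would address that question, while benzoyl, with a carbonyl link, and anilino, with a nitrogen-hydrogen link, would show how other links compare at this position.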